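The compounds below may be only part of what the source reports. "The series", "measured", "known", "first", "only" and "open" are said of these compounds alone.

The measured compounds:

Compound 1, `CC1=C(C(=O)OCC2CC2)C(c2ccco2)NC(=O)N1`: in an assay on membranes from HEK293 cells for displacement of a labelled ligand from adenosine receptor A2b (Homo sapiens), read by scintillation counting, with a stated time of 30 min (a lower number here means a stronger inhibitor, a higher number a weaker inhibitor), compound 1 gives 138 nM.
Compound 2, `CC1=C(C(=O)OC2CCC2)C(c2ccsc2)NC(=O)N1`: in this assay compound 2 gives 405 nM.
Compound 3, `CC1=C(C(=O)OC2CCCC2)C(c2ccsc2)NC(=O)N1`: in this assay compound 3 gives 659 nM.

Compound 3 has the highest of the three numbers. Its nearest neighbour is compound 2, and the move a 1.6-fold higher number from compound 2 to compound 3 (0.21 log units; within the scatter) is within the scatter, so the two cannot be told apart. Compound 1 is furthest away, and the gap between compound 1 and compound 3 lies beyond the scatter.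

Compound 4, `CC1=C(C(=O)OCC2CC2)C(c2ccsc2)NC(=O)N1`, keeps the rest of compound 3 and changes only the ester group: cyclopropylmethyl in place of cyclopentyl on an oxygen next to a carbonyl group. The one measured step at this position is a 1.6-fold higher number from compound 2 to compound 3 (0.21 log units; within the scatter), which was within the scatter, so changing the ring on this oxygen has not shown a clear effect so far. Compound 1 also carries cyclopropylmethyl on this oxygen, but it differs from compound 3 in a second place as well, so its lower number cannot be assigned to the ester alone. The expected step from compound 3 to compound 4 in this assay is therefore small, a 2.0-fold lower number from compound 3 to compound 4 (0.30 log units; within the scatter), with a slight lean toward a lower number. Compound 4 is estimated at 330 nM, with a likely range from 120 nM to 800 nM.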

Compound 4, inhibition constant: 724 nM
Compound 4: the middle estimate sits 2.2-fold (0.34 log units) below what was measured; low and high end bracket the measured number.
By their numbers in this assay, from the lowest: compound 1; then compounds 2, 3 and 4 (each within the scatter of the next).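

With thiophen-3-yl held fixed, the ester group on this oxygen shows no readable effect in this assay: cyclopropylmethyl in place of cyclopentyl gives a 1.1-fold higher number from compound 3 to compound 4 (0.04 log units; within the scatter), and cyclopropylmethyl in place of cyclobutyl gives a 1.8-fold higher number from compound 2 to compound 4 (0.25 log units; within the scatter). For the compounds shown here, the shared cyclopropylmethyl ester also gives the first clean reading at the saturated ring carbon, where thiophen-3-yl in place of furan-2-yl gives a 5.2-fold higher number from compound 1 to compound 4 (0.72 log units; beyond the scatter), so in this pair the ring on that carbon matters more than the ester steps seen so far. Nothing available explains either result.

As far as these compounds go, whether a straight butyl chain or a simple methyl on this oxygen would also leave the number unchanged remains open. From the compounds shown here alone, it is also open whether phenyl or thiophen-2-yl on the saturated ring carbon would match furan-2-yl or thiophen-3-yl.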